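A few compounds are considered here, and "the series" means these few. Any claim that something is new, unique, unknown or untested is made for them only; others in the source may bear on it.

Compound 1 `CCCCc1ccc(CN)c(=O)n1Cc1ccc(-c2ccccc2-c2nn[nH]n2)cc1` gives 20 nM in a functional assay (aorta) for antagonist activity, with Oryctolagus cuniculus as the target; a higher number here means a weaker inhibitor, a lower number a stronger inhibitor.
Compound 2 `CCCCc1ccc(CN(Cc2ccccc2)S(=O)(=O)c2ccccc2)c(=O)n1Cc1ccc(-c2ccccc2-c2nn[nH]n2)cc1` gives 20 nM in this assay.

Compound 2 stands level with compound 1; the two values lie within the usual scatter of the method, even though the two structures differ a great deal at one place. Compound 3 `CCCCc1ccc(CN(C)S(=O)(=O)c2ccccc2)c(=O)n1Cc1ccc(-c2ccccc2-c2nn[nH]n2)cc1` carries hydrogen in place of phenyl on a saturated chain carbon bound to a sulfonamide nitrogen; cut one bond further out, the same difference reads benzyl to methyl. Since compound 2 gave 20 nM, the same as compound 1 despite a far larger change at this place, the expected step is no change at the digits printed from compound 2 to compound 3 (within the scatter), none beyond the scatter. Compound 3 is therefore estimated at 20 nM, with a range from 7 nM to 60 nM.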

Compound 3, half-maximal inhibitory concentration: 2 nM
Compound 3: the middle estimate sits 10-fold (1.00 log units) above what was measured, and the stated range ends above it.
By their numbers in this assay, from the lowest: compound 3; then compounds 1 and 2 (each within the scatter of the next).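

In this assay, replacing benzyl with methyl gives a 10-fold lower number from compound 2 to compound 3 (1.00 log units; beyond the scatter), so the level values of compound 1 and compound 2 did not mean that this place is insensitive to what it carries. Methyl(phenylsulfonyl)amino in place of amino also gives a 10-fold lower number from compound 1 to compound 3 (1.00 log units; beyond the scatter), so the sulfonamide with methyl scores better than the plain amino group, while the one with benzyl does not. Nothing measured here explains these steps.

As far as these compounds go, it remains open whether an ethyl or propyl chain in place of methyl would keep the lower number. From the compounds shown here alone, it is also open how a carboxylic acid at the end of that chain would fare.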